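Phenyl for isopropyl on a seven-membered diamine ring

The source may hold more compounds than are shown below. What is called first, only, known or untested is meant among the compounds shown, and "the series" means these compounds.

Of the compounds shown here, three sharing one core have been measured in an assay on HEK293 cells for binding affinity to 5-hydroxytryptamine receptor 7 (Homo sapiens), read by radioligand binding, tested at 1 uM; on this read-out lower numbers stand for less inhibition and higher numbers for more inhibition at the one concentration tested (going by the name of the read-out). Compound 3 `CC(C)N1CCCN(CCn2ccc3ccc(Br)cc32)CC1` gives 92%, the highest of the three numbers. Compound 1 `Brc1ccc2ccn(CCN3CCN4CCCCC4C3)c2c1` gives 78%, which lies below compound 3 by a gap beyond the usual scatter. Compound 2 `Brc1ccc2ccn(CCN3CCN(C4CCCCC4)CC3)c2c1` gives 36%, the furthest from compound 3 and again beyond the scatter.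

Compound 4 `Brc1ccc2ccn(CCN3CCCN(c4ccccc4)CC3)c2c1` has not yet been measured in this assay. It differs from compound 3 in one place: phenyl in place of isopropyl on an amine nitrogen in a ring. Among the measured compounds shown here, no measured pair in this set shows the effect of that exact change, so any expectation rests only on the spread seen among compounds 1, 2 and 3.

Compound 4 is expected to fall below compound 3 in this assay, by a step estimated as a number 32 percentage points lower from compound 3 to compound 4 (beyond the scatter), larger than the scatter. The estimated value for compound 4 is 60%, within a range from 30% to 85%.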

Compound 4, a percentage reported as inhibition, at one concentration (the size of the read-out at that concentration, not a potency): 18%
The estimate for compound 4 lay 42 percentage points above the measured number; measured number below the stated range.
By their numbers in this assay, from the lowest: compound 4; then compound 2; then compound 1; then compound 3.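

In this assay, among the compounds shown here, the swap of isopropyl for phenyl on the amine nitrogen of the seven-membered ring gives a number 74 percentage points lower from compound 3 to compound 4 (beyond the scatter), and this is the first comparison in the set that changes one place only. It shows that this nitrogen is not a neutral position: with the shared core, the ethylene-free remainder of the molecule and the ring all held fixed, the group on this nitrogen alone takes compound 4 down to 18%. Nothing available here bears on why the step is so large.

A single pair cannot show whether a methyl, a benzyl or a pyridyl group on this nitrogen would read close to compound 3 or close to compound 4. It also leaves open whether the same swap would cost as much on a different diamine ring.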